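Imidazolylphenyl amide tested on the D3 aryl amide series

A few compounds are considered here, and "the series" means these few. Any claim that something is new, unique, unknown or untested is made for them only; others in the source may bear on it.

Three amides sharing one core have been measured in an assay on brain for displacement of a labelled ligand from D(3) dopamine receptor (Rattus norvegicus); on this read-out higher numbers stand for weaker inhibition and lower numbers for stronger inhibition. Compound 1 `CCCN(CC[C@H]1CC[C@H](NC(=O)/C=C/c2ccccc2OC)CC1)[C@H]1CCc2nc(N)sc2C1` gives 8.1 nM. Compound 2 `CCCN(CC[C@H]1CC[C@H](NC(=O)c2ccc3ccccc3n2)CC1)[C@H]1CCc2nc(N)sc2C1` gives 1.6 nM, and compound 3 `CCCN(CC[C@H]1CC[C@H](NC(=O)c2cccc3cnccc23)CC1)[C@H]1CCc2nc(N)sc2C1` gives 5.9 nM. Compound 3 thus stands second highest of the three numbers: it sits close to compound 1, as a 1.4-fold lower number from compound 1 to compound 3 (0.14 log units; within the scatter) shows, while a 3.7-fold higher number from compound 2 to compound 3 (0.57 log units; beyond the scatter) places it clearly apart from compound 2.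

The next compound, compound 4 `CCCN(CC[C@H]1CC[C@H](NC(=O)c2cccc(-n3ccnc3)c2)CC1)[C@H]1CCc2nc(N)sc2C1`, carries the change (3-(1H-imidazol-1-yl)phenyl in place of isoquinolin-5-yl on a carbonyl carbon). The measured steps that bear on this are those at the same carbonyl carbon: a 5.1-fold lower number from compound 1 to compound 2 (0.70 log units; beyond the scatter), a 1.4-fold lower number from compound 1 to compound 3 (0.14 log units; within the scatter) and a 3.7-fold higher number from compound 2 to compound 3 (0.57 log units; beyond the scatter). These show that exchanging the aryl group on the carbonyl moves this assay by modest amounts at most, with the quinolin-2-yl group giving the lowest number and the other two groups lying within the scatter of each other. Within the data shown here, no measured step involves a phenyl bearing a five-membered ring, so the direction is uncertain; a step of modest size, with the number more likely rising than falling, is expected, as a 1.4-fold higher number from compound 3 to compound 4 (0.13 log units; within the scatter) expresses. Compound 4 is therefore estimated at 8 nM, in the range 2.5 nM to 25 nM.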

Compound 4, inhibition constant: 1.1 nM
Compound 4: the middle estimate sits 7.3-fold (0.86 log units) above what was measured; measured number outside the range, below it.
By their numbers in this assay, from the lowest: compounds 4 and 2 (each within the scatter of the next); then compounds 3 and 1 (each within the scatter of the next).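

In this assay the 3-(1H-imidazol-1-yl)phenyl group on the carbonyl carbon reads alongside the quinolin-2-yl group, with a 1.5-fold lower number from compound 2 to compound 4 (0.16 log units; within the scatter) leaving the two together, while a 5.4-fold lower number from compound 3 to compound 4 (0.73 log units; beyond the scatter) and a 7.4-fold lower number from compound 1 to compound 4 (0.87 log units; beyond the scatter) set compound 4 clearly apart from the other two amides. The four amides therefore fall into two pairs, and a low number at this position no longer rests on the quinolin-2-yl group of compound 2 alone, since a quite different aryl group on the same carbonyl carbon reaches it too. No evidence is available on why the 3-(1H-imidazol-1-yl)phenyl and quinolin-2-yl groups read alike here.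

The compounds shown leave open how much of the step depends on the imidazole ring itself, which a plain phenyl, or a phenyl carrying a dimethylamino group or a carboxylic acid in its place, would help to settle. They also leave open whether these two pairs hold on any other dopamine receptor, or whether a different arrangement of the amides would appear there.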